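Swapping the aryl group on the shared core's amine

This account rests on a few compounds, and the source may have more. Where it says the series, first, only, none or still open, it means among the compounds named here.

Compound 1, `Cc1ccccc1Nc1nc(SCc2ccc(C(F)(F)F)cc2)nc2ccccc12`: 24400 nM in a functional assay on MGC-803 cells (Homo sapiens) for cytotoxicity, read by MTT assay, with a stated time of 72 h; a higher number here means a weaker inhibitor, a lower number a stronger inhibitor
Compound 2, `FC(F)(F)c1ccc(CSc2nc(Nc3cccc(Cl)c3)c3ccccc3n2)cc1`: 14600 nM in this assay

Going by the values given here, compound 2 stands at the lower of the two numbers so far, but its only neighbour is compound 1, and the step of a 1.7-fold lower number from compound 1 to compound 2 (0.22 log units; within the scatter) lies within the scatter, so the two compounds cannot be told apart on these data.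

Compound 3, `Cc1ccc(Nc2nc(SCc3ccc(C(F)(F)F)cc3)nc3ccccc23)cc1`, has not been measured. It differs from compound 2 in one place: 4-methylphenyl in place of 3-chlorophenyl on a nitrogen on an aromatic ring. Among the compounds with values here, the only measured step that bears on this change is the one from compound 1 to compound 2, where a different aryl group on the same nitrogen gave a 1.7-fold lower number from compound 1 to compound 2 (0.22 log units; within the scatter). One exchange of an aryl group at this position produced no change beyond the scatter, so for compound 3 a further exchange of that aryl group is expected to do the same in this assay: the step of a 1.2-fold higher number from compound 2 to compound 3 (0.09 log units; within the scatter) is expected to stay within the scatter. Compound 3 is therefore estimated at 18000 nM, with a range from 7000 nM to 45000 nM.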

Compound 3, half-maximal inhibitory concentration: 36100 nM
Compound 3: the middle estimate sits 2.0-fold (0.30 log units) below what was measured; the range from low to high includes it.
By their numbers in this assay, from the lowest: compounds 2, 1 and 3 (each within the scatter of the next, the first and the last beyond it).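

Going by these compounds alone, the exchange of 3-chlorophenyl for 4-methylphenyl on this nitrogen is the first at the position to move the number in this assay beyond the scatter, giving a 2.5-fold higher number from compound 2 to compound 3 (0.39 log units; beyond the scatter) in a step that is still modest. The exchange of 2-methylphenyl for 4-methylphenyl gives a 1.5-fold higher number from compound 1 to compound 3 (0.17 log units; within the scatter) and stays within the scatter, so these two methylphenyl groups cannot be told apart here, and compound 1 cannot be told apart from either compound 2 or compound 3. The position therefore responds to at least one exchange of its aryl group, although only the two ends of this small set separate, and nothing available here accounts for that difference.

The 3-chlorophenyl and 4-methylphenyl groups differ both in what they carry and in where they carry it, so 4-chlorophenyl and 3-methylphenyl would be needed to separate those two changes. On these data alone, it also remains open how the number would respond to groups of another kind on this nitrogen, such as a methoxyphenyl, a phenyl bearing a carboxylic acid, or a plain alkyl chain in place of the aryl ring.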